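The source may hold more compounds than are shown below. What is called first, only, known or untested is meant among the compounds shown, and "the series" means these compounds.

Measured so far:
- compound 1 `N#Cc1cc(C(=O)N2CS(=O)(=O)c3ccccc32)cc(Cl)c1O`: 3870 nM
- compound 2 `CCc1cc(C(=O)N2CS(=O)(=O)c3ccccc32)cc(C#N)c1O`: 12400 nM

In an ADME assay on the whole organism (Rattus norvegicus) for pharmacokinetics, read by HPLC, at a dose of 3 mg/kg by the oral route (on this read-out lower numbers stand for lower exposure and higher numbers for higher exposure at the dose given), compound 1 gives 3870 nM, the lower of the two numbers. Compound 3 `O=C(c1cc(Cl)c(O)c(C(F)(F)F)c1)N1CS(=O)(=O)c2ccccc21` carries trifluoromethyl in place of cyano on an aromatic carbon, ortho to a hydroxy group: trifluoromethyl in place of cyano on an aromatic carbon. Going by the values given here, the only measured step, a 3.2-fold higher number from compound 1 to compound 2 (0.51 log units; beyond the scatter), is modest and exchanges a different group at a different place, so it shows only that one such exchange can move this number. It gives no direction for the new change, and the expected result is no move beyond the scatter: a 1.0-fold lower number from compound 1 to compound 3 (0.01 log units; within the scatter). Compound 3 is estimated at 3800 nM (range 1300 nM to 11000 nM).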

Compound 3, maximal plasma concentration: 16400 nM
For compound 3 the middle estimate is 4.3-fold (0.64 log units) below the measured one; the measured number lies above the stated range.
By their numbers in this assay, from the lowest: compound 1; then compounds 2 and 3 (each within the scatter of the next).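

At the place ortho to a hydroxy group, the exchange does move the number in this assay: trifluoromethyl in place of cyano gives a 4.2-fold higher number from compound 1 to compound 3 (0.63 log units; beyond the scatter). So changes at two different places on the shared core, this one and the earlier swap of chloro for ethyl, have each given a higher number than compound 1. No measurement here offers a reason for this rise. From the compounds shown here alone, whether a methyl group or an amine at this place would also raise the number remains open. So does whether trifluoromethyl and ethyl together would raise it further.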